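From benzofuranyl to iodo on the methyl nucleoside

The compounds below may be only part of what the source reports. "The series", "measured", "known", "first", "only" and "open" are said of these compounds alone.

In a functional assay on HeLa S3 cells (Homo sapiens) for antiproliferative activity, read by XTT assay, with a stated time of 72 h (a lower number here means a stronger inhibitor, a higher number a weaker inhibitor), compound 3 (`Cc1ncnc2c1c(-c1cc3ccccc3o1)cn2[C@@H]1O[C@H](CO)[C@@H](O)[C@H]1O`) gives > 20000 nM as a limit, not a number. Compound 2 (`Cc1ncnc2c1c(-c1ccoc1)cn2[C@@H]1O[C@H](CO)[C@@H](O)[C@H]1O`) gives > 20000 nM as a limit too. Compound 1 (`COc1ncnc2c1c(-c1cc3ccccc3o1)cn2[C@@H]1O[C@H](CO)[C@@H](O)[C@H]1O`) gives 9240 nM as a true number. Among the compounds with values here, the one readable step is an at least 2.1-fold higher number from compound 1 to compound 3 (0.33 log units; beyond the scatter) with methyl in place of methoxy, while 1-benzofuran-2-yl in place of furan-3-yl gives a step that the two limits leave unreadable from compound 2 to compound 3 and so offers little. Compound 4 (`Cc1ncnc2c1c(I)cn2[C@@H]1O[C@H](CO)[C@@H](O)[C@H]1O`) carries iodo in place of 1-benzofuran-2-yl on an aromatic carbon and neither step involves iodo. Compound 3 belongs to the limit of > 20000 nM in this assay, at which 2 of the 3 values shown sit, so any readable change would go downward. The expected step is an at least 2.0-fold lower number from compound 3 to compound 4 (0.30 log units; that floor lies within the scatter) toward a lower number, small and uncertain. Compound 4 is expected at 10000 nM with a range of 2000 nM to 40000 nM as the estimate.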

Compound 4, half-maximal inhibitory concentration: 4080 nM
Estimate against measurement, compound 4: 2.5-fold (0.39 log units) above; measured number inside the range.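

On the methyl core, iodo at this position gives an at least 4.9-fold lower number from compound 3 to compound 4 (0.69 log units; beyond the scatter) and an at least 4.9-fold lower number from compound 2 to compound 4 (0.69 log units; beyond the scatter) in this assay and so provides the first readable gain there. A single iodine atom thus gives a lower number than either ring-bearing group shown on this core. Both sizes are floors, since each starting point is a limit and not a number: the limit of > 20000 nM in this assay, at which 2 of the 4 values shown sit.

The compounds shown leave open how large the two steps truly are, and whether iodo would also lower the number on the methoxy core of compound 1. They also leave open what bromo or an amine would give at this position.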